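Removing a Chlorine: Paw Edema Inhibition Expected

The compounds below may be only part of what the source reports. "The series", "measured", "known", "first", "only" and "open" are said of these compounds alone.

Compound 2 `CCOC(=O)c1c(-c2ccc(Cl)cc2)n(-c2ccc(C(=O)NNC(=O)CO[N+](=O)[O-])cc2)[nH]c1=O` gives the lowest of the two numbers measured in a functional assay on the whole organism (strain Wistar) for inhibition, with Rattus norvegicus as the target, read by paw edema, with stated times of 2 h and 1 h, at a dose of 6 mg/kg by the oral route; a lower number here means less inhibition, a higher number more inhibition at the dose given (going by the name of the read-out): compound 2 shows 10.4%, while compound 1 `CCOC(=O)c1c(-c2ccccc2OC)n(-c2ccc(C(=O)NNC(=O)CO[N+](=O)[O-])cc2)[nH]c1=O` shows 30.7%, a step of a number 20.3 percentage points lower from compound 1 to compound 2 (beyond the scatter). Compound 3 `CCOC(=O)c1c(-c2ccccc2)n(-c2ccc(C(=O)NNC(=O)CO[N+](=O)[O-])cc2)[nH]c1=O` carries hydrogen in place of chloro on an aromatic carbon. Among the measured compounds shown here, the only step seen so far exchanged one substituted phenyl for another; no measured step removes a chloro on its own, so that step bears only loosely here. Compound 3 is therefore expected to change little, with an estimated step of a number 7.6 percentage points higher from compound 2 to compound 3 (within the scatter). The estimate for compound 3 is 18%, with a range from 5% to 35%.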

Compound 3, a percentage reported as inhibition, in the whole organism at one dose (the size of the read-out at that dose, not a potency): 57.8%
Beside the measured number, compound 3's estimate is 39.8 percentage points below it; the whole stated range lies below it.
By their numbers in this assay, from the lowest: compound 2; then compound 1; then compound 3.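

In this assay, hydrogen in place of chloro gives a number 47.4 percentage points higher from compound 2 to compound 3 (beyond the scatter), so this single atom on the aromatic carbon makes a large difference, which the earlier exchange of one substituted phenyl for another could not isolate. Hydrogen in place of methoxy gives a number 27.1 percentage points higher from compound 1 to compound 3 (beyond the scatter), so among these three compounds the unsubstituted phenyl stands highest and either group goes with less inhibition. Nothing available explains these differences.

From the compounds shown here alone, it remains open whether a fluoro or methyl group in the chloro's place would keep the number of compound 3 or lower it. Going by these compounds, an amine or a carboxylic acid there is equally open.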